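Moving a Methoxy Group on a Shared Core

The source may hold more compounds than are shown below. What is called first, only, known or untested is meant among the compounds shown, and "the series" means these compounds.

Of the compounds shown here, three built on one core have been tested in a functional assay on Huh-7 cells (Homo sapiens) for inhibition, read by sulforhodamine B assay, with a stated time of 72 h; on this read-out higher numbers stand for weaker inhibition and lower numbers for stronger inhibition. Compound 1 `COc1ccc(OC)c(C(=O)/C=C/c2cn(-c3ccccc3)nc2-c2ccsc2)c1` gives 2100 nM. Compound 2 `COc1ccc(C(=O)/C=C/c2cn(-c3ccccc3)nc2-c2ccsc2)c(OC)c1` gives 3000 nM, and compound 3 `COc1ccc(OC)c(C(=O)/C=C/c2cn(-c3ccccc3)nc2-c2ccncc2)c1` gives 1700 nM. The change from compound 1 to compound 2 is 2,4-dimethoxyphenyl in place of 2,5-dimethoxyphenyl on a carbonyl carbon, and it made a 1.4-fold higher number from compound 1 to compound 2 (0.15 log units; within the scatter). The change from compound 1 to compound 3 is pyridin-4-yl in place of thiophen-3-yl on an aromatic carbon, and it made a 1.2-fold lower number from compound 1 to compound 3 (0.09 log units; within the scatter). All three numbers sit close together.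

Compound 4 `COc1ccc(C(=O)/C=C/c2cn(-c3ccccc3)nc2-c2ccncc2)c(OC)c1` has not yet been measured in this assay. It differs from compound 3 by 2,4-dimethoxyphenyl in place of 2,5-dimethoxyphenyl on a carbonyl carbon, the same change already seen between compound 1 and compound 2, made once there and once more here, at a place described in the same words both times. The two cores differ as set out in pyridin-4-yl in place of thiophen-3-yl on an aromatic carbon.

Since the earlier change gave a 1.4-fold higher number from compound 1 to compound 2 (0.15 log units; within the scatter), the step expected for compound 4 is a 1.4-fold higher number from compound 3 to compound 4 (0.15 log units; within the scatter), resting on that single measured pair and so held loosely. Compound 4 is therefore estimated at 2400 nM, with a likely range from 1200 nM to 4800 nM.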

Compound 4, half-maximal inhibitory concentration: 4400 nM
Compound 4: the middle estimate sits 1.8-fold (0.26 log units) below what was measured; the range from low to high includes it.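

In this assay, among the compounds shown here, placing 2,4-dimethoxyphenyl where 2,5-dimethoxyphenyl stood on the carbonyl carbon gives a 2.6-fold higher number from compound 3 to compound 4 (0.41 log units; beyond the scatter), and although only this step lies beyond the scatter, it cannot be told apart from the step for the same change on the other core: the same change on two cores in this assay, a 1.4-fold higher number (0.15 log units; within the scatter) from compound 1 to compound 2 and a 2.6-fold higher number (0.41 log units; beyond the scatter) from compound 3 to compound 4, 1.8-fold (0.26 log units) apart, within the scatter of two such steps. The swap of thiophen-3-yl for pyridin-4-yl, now seen with 2,4-dimethoxyphenyl in place, gives a 1.5-fold higher number from compound 2 to compound 4 (0.17 log units; within the scatter), and it also agrees with its earlier counterpart: the same change on two cores in this assay, a 1.2-fold lower number (0.09 log units; within the scatter) from compound 1 to compound 3 and a 1.5-fold higher number (0.17 log units; within the scatter) from compound 2 to compound 4, 1.8-fold (0.26 log units) apart, within the scatter of two such steps. So both changes carry from one core to the other as far as these compounds can show, but with only two pairs for each change, this neither proves that the effects are the same on every core nor fixes their true size.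

All the compounds shown keep two methoxy groups on the ring at the carbonyl, so it stays open how a single methoxy group, a hydroxyl or a fluorine there would read. Also open, as far as these compounds go, is what a saturated chain would do in place of the double-bonded chain.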